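The source may report more compounds than this note shows. Statements on the series, on what has been measured and on what is new or still open speak of the compounds shown alone.

Compound 1 `ClCc1ccc(Cn2cnc3c(Cl)ncnc32)cc1` and compound 3 `ClCc1ccc(Cn2cnc3c(Cl)nc(Cl)nc32)cc1` share one core and differ at a single spot: chloro in place of hydrogen on an aromatic carbon. In a functional assay on NCI-H460 cells (Homo sapiens) for cytotoxicity, read by sulforhodamine B assay, with a stated time of 48 h (on this read-out lower numbers stand for stronger inhibition of growth and higher numbers for weaker inhibition of growth), compound 1 gives 50 nM, while compound 3 gives 2400 nM, so that one change made a 48-fold higher number from compound 1 to compound 3 (1.68 log units; beyond the scatter). Compound 2 `ClCc1ccccc1Cn1cnc2ncnc(Cl)c21` is built from the same atoms as compound 1, joined differently; the difference between the two cores is not broken down here. In this assay compound 2 gives 13500 nM, the highest number of the three. Compound 4 `ClCc1ccccc1Cn1cnc2nc(Cl)nc(Cl)c21` carries the same change relative to compound 2: chloro in place of hydrogen on an aromatic carbon. The surroundings of the place are described in the same words in both pairs, so this is the same change, made in two pairs. Because a 48-fold higher number from compound 1 to compound 3 (1.68 log units; beyond the scatter) was seen, a step in the same direction is expected here, namely an 11-fold higher number from compound 2 to compound 4 (1.05 log units; beyond the scatter). Compound 4 is therefore estimated at 150000 nM, with an expected range from 30000 nM to 800000 nM, and a real chance that only a limit is reported.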

Compound 4, concentration for 50% growth inhibition: 2390 nM
Beside the measured number, compound 4's estimate is 63-fold (1.80 log units) above it, and the stated range ends above it.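

In this assay the chloro group in place of hydrogen gave a 5.6-fold lower number from compound 2 to compound 4 (0.75 log units; beyond the scatter) and so moved the number the opposite way from the first pair. The same change therefore did not carry over from one core to the other, in size or in direction: the same change on two cores in this assay, a 48-fold higher number (1.68 log units; beyond the scatter) from compound 1 to compound 3 and a 5.6-fold lower number (0.75 log units; beyond the scatter) from compound 2 to compound 4, 270-fold (2.43 log units) apart, beyond the scatter of two such steps. This shows that a step measured on one core is a poor guide to the other core in this series, but two pairs do not show why the cores differ or how the change would behave on a further core.

The compounds shown leave open whether an amine or a methoxy group on the aromatic carbon between two ring nitrogen atoms would also give opposite steps on these two cores.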